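Dropping a Fluoro Group From Compound 1

The compounds below may be only part of what the source reports. "The series", "measured", "known", "first", "only" and "open" are said of these compounds alone.

Of the compounds shown here, three built on one shared core have been measured in a functional assay for inhibition, with Rattus norvegicus as the target; a lower number here means a stronger inhibitor, a higher number a weaker inhibitor. Compound 1 `CCC(C)(C)/N=c1\c(O)c(O)\c1=N/Cc1ccc(F)c(F)c1` gives 1600 nM. Compound 2 `CC(C)(C)/N=c1\c(O)c(O)\c1=N/Cc1c(F)cccc1F` gives 7500 nM in this assay, and compound 3 `CC(C)(C)/N=c1\c(O)c(O)\c1=N/Cc1ccccc1F` gives 2100 nM. Compound 1 and compound 3 lie within the usual scatter of each other, while compound 2 stands apart from both. How the core of compound 1 differs from that of compound 2 is not broken down here.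

Compound 2 and compound 3 differ in one place: hydrogen in place of fluoro on an aromatic carbon. That change gave a 3.6-fold lower number from compound 2 to compound 3 (0.55 log units; beyond the scatter).

Compound 4 `CCC(C)(C)/N=c1\c(O)c(O)\c1=N/Cc1ccc(F)cc1` has not been measured yet. It relates to compound 1 by hydrogen in place of fluoro on an aromatic carbon. For the measured compounds named here, this is the same kind of change as the one from compound 2 to compound 3, but not the same: there the leaving fluoro sat ortho to a large group and meta to a fluoro group, whereas here it sits ortho to a fluoro group and meta to a large group. The earlier step is therefore only a loose guide. Compound 4 is expected to give about 1000 nM in this assay, with a range from 400 nM to 3000 nM. The expected step is a 1.6-fold lower number from compound 1 to compound 4 (0.20 log units; within the scatter), estimated smaller than the measured one because the step of a 3.6-fold lower number from compound 2 to compound 3 (0.55 log units; beyond the scatter) arose at a different place on the ring.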

Compound 4, half-maximal inhibitory concentration: 360 nM
Compound 4: the middle estimate sits 2.8-fold (0.44 log units) above what was measured; the measured number lies below the stated range.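

Replacing the fluoro group with hydrogen on an aromatic carbon gave a 4.4-fold lower number from compound 1 to compound 4 (0.65 log units; beyond the scatter) in this assay. Set beside the earlier case, the same kind of change carried over between the two cores with a step of much the same size: the same change on two cores in this assay, a 3.6-fold lower number (0.55 log units; beyond the scatter) from compound 2 to compound 3 and a 4.4-fold lower number (0.65 log units; beyond the scatter) from compound 1 to compound 4, 1.2-fold (0.09 log units) apart, within the scatter of two such steps. For the compounds shown here, this rests on only two pairs, and the leaving fluoro sits at a different place on the ring in each, so it shows agreement in these two cases but does not show that the step would hold on other cores or at other places on the ring, and it does not explain why the number falls.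

The compounds shown leave open what hydrogen in place of the remaining fluoro group of compound 4 would give, and whether a chloro or methoxy group at the place vacated in compound 1 would behave more like fluoro or like hydrogen. They also leave open whether the step would keep its size if a longer chain took the place of the branched alkyl group on the shared core.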